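Adding a Chloro Group to the Urea Aryl Ring

The source may hold more compounds than are shown below. What is called first, only, known or untested is meant among the compounds shown, and "the series" means these compounds.

Of the compounds shown here, three sharing one core have been measured in a functional assay on BT-549 cells (Homo sapiens) for inhibition, read by sulforhodamine B assay, with a stated time of 48 h; on this read-out higher numbers stand for weaker inhibition of growth and lower numbers for stronger inhibition of growth. Compound 1 `O=C(Nc1cccc(-n2cc(-c3ccncc3)c(-c3ccc(Cl)c(O)c3)n2)c1)Nc1cccc(C(F)(F)F)c1` gives 6510 nM, the highest of the three numbers, meaning the weakest growth inhibition here. Compound 2 `COc1cc(-c2nn(-c3cccc(NC(=O)Nc4cccc(C(F)(F)F)c4)c3)cc2-c2ccncc2)ccc1Cl` gives 1250 nM, and compound 3 `O=C(Nc1cccc(-n2cc(-c3ccncc3)c(-c3ccc(Cl)c(O)c3)n2)c1)Nc1cc(C(F)(F)F)cc(C(F)(F)F)c1` gives 1090 nM. The step of a 5.2-fold lower number from compound 1 to compound 2 (0.72 log units; beyond the scatter) and the step of a 6.0-fold lower number from compound 1 to compound 3 (0.78 log units; beyond the scatter) are both beyond the scatter and both lead to stronger inhibition.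

Compound 4 `O=C(Nc1cccc(-n2cc(-c3ccncc3)c(-c3ccc(Cl)c(O)c3)n2)c1)Nc1ccc(Cl)c(C(F)(F)F)c1` differs from compound 1 by a single change: chloro in place of hydrogen on an aromatic carbon. The closest guide is the step from compound 1 to compound 3, where a second trifluoromethyl group entered the same terminal ring and gave a 6.0-fold lower number from compound 1 to compound 3 (0.78 log units; beyond the scatter). The change to compound 4 also adds a single group to that ring, though a smaller one, in a different place. The step from compound 1 to compound 2 touches a different part of the molecule and is less informative.

A modest improvement in this assay is therefore expected, somewhat smaller than the step seen with compound 3. The expected step is a 3.4-fold lower number from compound 1 to compound 4 (0.53 log units; beyond the scatter). For compound 4 the estimated value in this assay is 1900 nM, with a likely range from 700 nM to 5000 nM.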

Compound 4, concentration for 50% growth inhibition: 1250 nM
Beside the measured number, compound 4's estimate is 1.5-fold (0.18 log units) above it; low and high end bracket the measured number.
By their numbers in this assay, from the lowest: compounds 3, 2 and 4 (each within the scatter of the next); then compound 1.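

In this assay, chloro on an aromatic carbon, ortho to a trifluoromethyl group and para to a large group, gives a 5.2-fold lower number from compound 1 to compound 4 (0.72 log units; beyond the scatter) and so stronger growth inhibition. Before this result, compound 3 was the only sign that adding to this terminal ring could help, and there the added group was a second trifluoromethyl in a different place; now a group of 1 heavy atom also gives a gain beyond the scatter, with compound 3 at 1090 nM and compound 4 at 1250 nM lying within the scatter of each other. No measurement here bears on how the chloro group produces this gain.

The compounds shown leave open whether the gain is particular to chloro or would also appear with fluoro, bromo, methyl, an amine or a carboxylic acid at this position. They also leave open whether this chloro group would add to the step seen with the methyl ether of compound 2 if both changes were placed in one molecule.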